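The source may hold more compounds than are shown below. What is called first, only, known or untested is meant among the compounds shown, and "the series" means these compounds.

In a functional assay on brain (Rattus norvegicus, strain Wistar) for inhibition (on this read-out lower numbers stand for stronger inhibition and higher numbers for weaker inhibition), compound 1 `CCCc1ccc(-c2c(C)[nH]c(=O)n2C2CCCCC2)cc1` gives 13900 nM as its result. Among the compounds with values here, only one other compound has been measured there: compound 2 `CCCCCCOc1ccc(-c2c(C)[nH]c(=O)n2C2CCCCC2)cc1` gives 8500 nM and so lies within the scatter of compound 1. Within the data shown here, compound 3 `CCCCCCCCCCCCc1ccc(-c2c(C)[nH]c(=O)n2C2CCCCC2)cc1` has no measurement yet. It differs from compound 1 by nonyl in place of hydrogen on a saturated chain carbon, three bonds along the chain from an aromatic carbon and so carries nonyl in place of hydrogen on a saturated chain carbon, three bonds along the chain from an aromatic carbon. Cut one bond further out, the same difference reads methyl to decyl. Among the measured compounds shown here, the one measured step that bears on this is hexyloxy in place of propyl on an aromatic carbon, which amounts to a 1.6-fold lower number from compound 1 to compound 2 (0.21 log units; within the scatter) and is a different change at a different place, so it is only a weak guide. For the measured compounds named here, no measured compound carries a chain as long as the one in compound 3. Going by the values given here, with compound 2 at 8500 nM as the only guide, a moderate step to a lower number is expected in this assay rather than a large one. The estimated change is a 2.8-fold lower number from compound 1 to compound 3 (0.44 log units; beyond the scatter) in size. Compound 3 is expected to read 5000 nM (estimated range 1200 nM to 16000 nM).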

Compound 3, half-maximal inhibitory concentration: > 100000 nM
Compound 3 gave a limit, no number; the forecaster's own chance of this, stated with the estimate: 10%; at least 20-fold (1.30 log units) between middle value and limit.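

In this assay, compound 3 reads only as a limit of the assay and not as a number: the limit of > 100000 nM in this assay, at which 1 of the 3 values shown sits. Nonyl in place of hydrogen on a saturated chain carbon, three bonds along the chain from an aromatic carbon, therefore weakens inhibition, with an at least 7.1-fold higher number from compound 1 to compound 3 (0.85 log units; beyond the scatter). The earlier change, hexyloxy in place of propyl on an aromatic carbon, gave a 1.6-fold lower number from compound 1 to compound 2 (0.21 log units; within the scatter), so only the new step shows that a change in the group carried at this end of the shared core can move this read-out beyond the scatter, and in the direction of weaker inhibition.

The true size of the loss remains unknown, since the step is bounded only on one side, and the compounds shown do not tell at what length between the propyl of compound 1 and the much longer chain of compound 3 inhibition begins to fall away. They also leave open whether a pentyl or octyl chain at the same place would keep the inhibition of compound 1, and whether an amine or a carboxylic acid at the end of a long chain would read differently from the plain carbon chain.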